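A few compounds are considered here, and "the series" means these few. Any claim that something is new, unique, unknown or untested is made for them only; others in the source may bear on it.

Compound 1: `O=C(O)CCc1ccc(NCc2cccc(Br)c2)cc1`, 174 nM
Compound 2: `O=C(O)CCc1ccc(OCc2cccc(C(F)(F)F)c2)cc1`, 83.2 nM
Compound 3: `O=C(O)CCc1ccc(NCc2ccccc2-c2ccccc2)cc1`, 1070 nM

Three compounds share the propanoic acid side chain on a benzene ring and differ in the linker and in the substituted benzyl group. In a functional assay on 1321-N1 cells for agonist activity at Free fatty acid receptor 1 (Homo sapiens), read by calcium flux (a lower number here means that less compound is needed, a higher number that more compound is needed for the effect), compound 2 gives 83.2 nM, the lowest of the three numbers. Compound 1 stands nearest to it, and its value 174 nM lies beyond the usual scatter from that of compound 2. Compound 3, which carries a phenyl on its benzyl ring and an amine linker, gives 1070 nM, the highest of the three numbers and well beyond the scatter from compound 2.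

Compound 4, `Cc1ccc(-c2cccc(COc3ccc(CCC(=O)O)cc3)c2)cc1`, is not yet measured. It differs from compound 2 in one place: 4-methylphenyl in place of trifluoromethyl on an aromatic carbon, meta to a large group. Going by the values given here, no pair of measured compounds isolates this single change, so the size of the step is open. Among the compounds with values here, compound 3 is the only measured compound with an added aromatic ring on the benzyl group, but its linker and the place of the ring differ too, so its value cannot be read as a guide for this step.

Compound 4 is therefore expected to give about 50 nM in this assay, with a range from 12 nM to 250 nM, a step from compound 2 to compound 4 of a 1.7-fold lower number from compound 2 to compound 4 (0.22 log units; within the scatter) that is estimated to stay within or only slightly beyond the scatter.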

Compound 4, half-maximal effective concentration: 490 nM
For compound 4 the middle estimate is 9.8-fold (0.99 log units) below the measured one, and the stated range ends below it.
By their numbers in this assay, from the lowest: compound 2; then compound 1; then compound 4; then compound 3.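

In this assay, 4-methylphenyl in place of trifluoromethyl on an aromatic carbon, meta to a large group, gives a 5.9-fold higher number from compound 2 to compound 4 (0.77 log units; beyond the scatter). Going by these compounds alone, this is the first change confined to this place, and it shows that the number responds to the group carried there, as the step lies beyond the scatter. Nothing given here accounts for the step, and what lies behind it remains unknown.

As far as these compounds go, with only one replacement for trifluoromethyl, it remains open whether the higher number goes with the added six-membered aromatic ring, with its methyl group, or simply with the move from four heavy atoms to seven, and a plain phenyl, a chlorine or a methoxy group at this place would help to separate these readings. From the compounds shown here alone, it also remains open whether 4-methylphenyl at this place would give a step of similar size on a compound with the amine linker of compound 1, since the present step is read only on the ether-linked pair.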